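Chalcone series: nitro for fluoro-methoxy on the styryl ring

This account rests on a few compounds, and the source may have more. Where it says the series, first, only, none or still open, it means among the compounds named here.

Measured so far:
compound 1 `COc1ccc(/C=C/C(=O)c2ccc(OC)c3c2OC(C)(C)C=C3)c(F)c1` — 4880 nM
compound 2 `CCN(CC)c1ccc(/C=C/C(=O)c2ccc(OC)c3c2OC(C)(C)C=C3)cc1` — 610 nM
compound 3 `COc1ccc(C(=O)/C=C/c2ccc(N3CCCC3)cc2)c2c1C=CC(C)(C)O2` — 7370 nM

In a functional assay on SK-OV-3 cells (Homo sapiens) for antiproliferative activity, read by MTT assay, with a stated time of 24 h (on this read-out higher numbers stand for weaker inhibition and lower numbers for stronger inhibition), compound 1 stands second highest of the three numbers; its nearest neighbour is compound 3, within the scatter, while compound 2 lies well below it, beyond the scatter. Among the measured compounds shown here, the only single-point step measured, a 12-fold higher number from compound 2 to compound 3 (1.08 log units; beyond the scatter), concerns the amine on the styryl ring and does not touch the change now followed. Compound 4 `COc1ccc(C(=O)/C=C/c2ccc([N+](=O)[O-])cc2)c2c1C=CC(C)(C)O2` differs from compound 1 by 4-nitrophenyl in place of 2-fluoro-4-methoxyphenyl on a double-bonded chain carbon bound to a double-bonded chain carbon. For the measured compounds named here, no measured step bears on this exchange, so the expectation rests on compound 1 alone and on the broad spread between compound 2 and compound 3. Compound 4 is therefore expected to give 5000 nM, within 1500 nM to 16000 nM, a step of a 1.0-fold higher number from compound 1 to compound 4 (0.01 log units; within the scatter) that is expected to stay within the scatter.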

Compound 4, half-maximal inhibitory concentration: 3420 nM
Beside the measured number, compound 4's estimate is 1.5-fold (0.16 log units) above it; measured number inside the range.
By their numbers in this assay, from the lowest: compound 2; then compounds 4, 1 and 3 (each within the scatter of the next, the first and the last beyond it).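

In this assay, 4-nitrophenyl takes the place of 2-fluoro-4-methoxyphenyl on this chain carbon without a change beyond the scatter (a 1.4-fold lower number from compound 1 to compound 4 (0.15 log units; within the scatter)). On the aromatic carbon of the styryl ring, nitro falls between the two amines, improving on pyrrolidin-1-yl (a 2.2-fold lower number from compound 3 to compound 4 (0.33 log units; beyond the scatter)) but not matching diethylamino (a 5.6-fold higher number from compound 2 to compound 4 (0.75 log units; beyond the scatter)). Nothing available accounts for these differences.

From the compounds shown here alone, it remains open whether a primary amine or morpholine on that aromatic carbon would follow diethylamino or pyrrolidin-1-yl. Also open, going by these compounds, is how a phenyl ring carrying only fluoro or only methoxy would compare with compound 1.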